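The compounds below may be only part of what the source reports. "The series", "measured", "known", "first", "only" and "open" are said of these compounds alone.

In a functional assay on MDA-MB-231 cells (Homo sapiens) for cytotoxicity, read by MTT assay, with a stated time of 72 h (a lower number here means a stronger inhibitor, a higher number a weaker inhibitor), compound 1 (`Cc1ccc(NC(=O)CN2CCN(c3nnc(Cc4ccncc4)c4ccccc34)CC2)c(C)c1`) stands at 240 nM and compound 2 (`O=C(CN1CCN(c2nnc(Cc3ccncc3)c3ccccc23)CC1)Nc1cccc(Br)c1`) at 1.7 nM while compound 3 (`O=C(CN1CCN(c2nnc(Cc3ccccc3)c3ccccc23)CC1)Nc1ccc(F)c(C(F)(F)F)c1`) gives 760 nM as the highest of the three numbers. Compound 4 (`Cc1cccc(Cl)c1NC(=O)CN1CCN(c2nnc(Cc3ccccc3)c3ccccc23)CC1`) is still unmeasured and differs from compound 3 by 2-chloro-6-methylphenyl in place of 4-fluoro-3-(trifluoromethyl)phenyl on an amide-type nitrogen in one place: 2-chloro-6-methylphenyl replaces 4-fluoro-3-(trifluoromethyl)phenyl on an amide-type nitrogen. Among the compounds with values here, the only measured step at this place is the large one a 140-fold lower number from compound 1 to compound 2 (2.15 log units; beyond the scatter) on the core of compound 1, so this place can matter greatly. Within the data shown here, no measured step involves the incoming group or starts from the core of compound 3, so no firm direction can be read. The expected change is a 1.9-fold lower number from compound 3 to compound 4 (0.28 log units; within the scatter) and no step beyond the scatter is expected in this assay for now. For compound 4 the estimated value is 400 nM with an expected range from 60 nM to 2500 nM in this wide estimate.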

Compound 4, half-maximal inhibitory concentration: 3920 nM
For compound 4 the middle estimate is 9.8-fold (0.99 log units) below the measured one, and the stated range ends below it.
By their numbers in this assay, from the lowest: compound 2; then compound 1; then compound 3; then compound 4.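

In this assay, the group on the amide-type nitrogen also matters on the core of compound 3, not only on the core of compound 1, with a 5.2-fold higher number from compound 3 to compound 4 (0.71 log units; beyond the scatter) as the first step measured there. On this core, 2-chloro-6-methylphenyl gives a weaker inhibitor than 4-fluoro-3-(trifluoromethyl)phenyl. No measured evidence explains this difference. Going by these compounds, it remains open whether 3-bromophenyl would give as low a number on the core of compound 3 as on the core of compound 1. On these data alone, the effect of an amine or a carboxylic acid on this phenyl ring also remains open.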